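Moving two methoxy groups on an unmeasured analogue

The source may hold more compounds than are shown below. What is called first, only, known or untested is meant among the compounds shown, and "the series" means these compounds.

Three compounds share one core, and all are judged in a functional assay on K562 cells (Homo sapiens) for cytotoxicity, read by MTT assay, with a stated time of 72 h; a lower number here means a stronger inhibitor, a higher number a weaker inhibitor. Compound 1 `COc1cccc(/C=C/C(=O)c2cc3ccc(O)cc3oc2=O)c1OC` carries a free hydroxyl on that core and a 2,3-dimethoxyphenyl on its chain; in this assay compound 1 gives 14600 nM. Compound 2 `COc1cccc(COc2ccc3cc(C(=O)/C=C/c4cc(OC)ccc4OC)c(=O)oc3c2)c1` instead carries a benzyl ether on the core and a 2,5-dimethoxyphenyl on the chain. For compound 2 this assay reports only a limit, > 100000 nM, which is the limit of > 100000 nM in this assay, at which 1 of the 2 values shown sits, rather than a measured number.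

Compound 3 `COc1cccc(COc2ccc3cc(C(=O)/C=C/c4cccc(OC)c4OC)c(=O)oc3c2)c1` has not yet been measured. It is built from the same atoms as compound 2, joined differently: 2,3-dimethoxyphenyl in place of 2,5-dimethoxyphenyl on a double-bonded chain carbon bound to a double-bonded chain carbon. Among the compounds with values here, no measured pair shows this exact change on this core, so its effect is unknown from the data. The limit for compound 2 leaves room only downward, and the expectation is a modest step from compound 2 to compound 3, an at least 1.4-fold lower number from compound 2 to compound 3 (0.15 log units; that floor lies within the scatter), that may still fall within the scatter. Compound 3 is therefore estimated at 70000 nM, with a likely range from 15000 nM to 300000 nM.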

Compound 3, half-maximal inhibitory concentration: 45500 nM
The estimate for compound 3 lay 1.5-fold (0.19 log units) above the measured number; low and high end bracket the measured number.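

In this assay, 2,3-dimethoxyphenyl in place of 2,5-dimethoxyphenyl on the chain gives an at least 2.1-fold lower number from compound 2 to compound 3 (0.34 log units; beyond the scatter), so with the atoms unchanged, how the two methoxy groups are joined to this ring makes a difference that lies beyond the scatter. The full size of that step stays unknown because compound 2 carries a limit and not a number: the limit of > 100000 nM in this assay, at which 1 of the 3 values shown sits.

With 2,3-dimethoxyphenyl held constant on the chain, 3-methoxybenzyl in place of hydrogen on an oxygen on an aromatic ring gives a 3.1-fold higher number from compound 1 to compound 3 (0.49 log units; beyond the scatter), so covering the free hydroxyl of compound 1 weakens the result by a modest step, yet compound 3 still gives a measured number rather than a limit.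

On these data alone, the 2,5-dimethoxyphenyl appears here only alongside the benzyl ether, so whether the same change on the chain would matter as much on the core with its free hydroxyl remains open. Also open, as far as these compounds go, is how this assay would respond to other groups on that oxygen, such as a chain ending in an amine or a carboxylic acid.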